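Hydroxylated aryl hydrazones on an oxadiazole core: cytotoxicity

The source may report more compounds than this note shows. Statements on the series, on what has been measured and on what is new or still open speak of the compounds shown alone.

The measured compounds:
compound 1, `COc1ccccc1-c1nnc(-c2ccc(C(=O)N/N=C/c3ccc([N+](=O)[O-])cc3)cc2)o1`, 203000 nM
compound 2, `COc1ccccc1-c1nnc(-c2ccc(C(=O)N/N=C/c3cccc(F)c3)cc2)o1`, 353000 nM
compound 3, `COc1ccccc1-c1nnc(-c2ccc(C(=O)N/N=C/c3ccc(O)c(O)c3)cc2)o1`, 100000 nM

In an ADME assay on THP-1 cells (Homo sapiens) for cytotoxicity (on this read-out higher numbers stand for weaker inhibition and lower numbers for stronger inhibition), compound 3 gives the lowest number of the three, and both of its steps from the other compounds are beyond the scatter: a 2.0-fold lower number from compound 1 to compound 3 (0.31 log units; beyond the scatter), and a 3.5-fold lower number from compound 2 to compound 3 (0.55 log units; beyond the scatter). The step between compound 1 and compound 2 stays within the scatter: a 1.7-fold higher number from compound 1 to compound 2 (0.24 log units; within the scatter).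

Compound 4, `COc1ccccc1-c1nnc(-c2ccc(C(=O)N/N=C/c3c(O)cc(O)cc3O)cc2)o1`, has not been measured. It differs from compound 3 in one place: 2,4,6-trihydroxyphenyl in place of 3,4-dihydroxyphenyl on a carbon with a double bond to nitrogen. The two steps that bear on this change are those leading into compound 3, where the 3,4-dihydroxyphenyl ring replaced the 4-nitrophenyl or the 3-fluorophenyl ring and the number fell by a modest amount each time. A further hydroxylated ring is thus expected to give a number close to or somewhat below that of compound 3, so compound 4 is expected to show a 1.3-fold lower number from compound 3 to compound 4 (0.10 log units; within the scatter), a step that may well stay within the scatter. Compound 4 is estimated at 80000 nM, with a range from 30000 nM to 250000 nM.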

Compound 4, half-maximal inhibitory concentration: 12400 nM
Beside the measured number, compound 4's estimate is 6.5-fold (0.81 log units) above it; measured number below the stated range.
By their numbers in this assay, from the lowest: compound 4; then compound 3; then compounds 1 and 2 (each within the scatter of the next).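

In this assay, among these compounds, the aryl ring on the carbon with a double bond to nitrogen proves more sensitive than the earlier compounds showed: an 8.1-fold lower number from compound 3 to compound 4 (0.91 log units; beyond the scatter) is a larger step than any among compounds 1, 2 and 3. Hydroxylated rings are therefore not interchangeable here, since 2,4,6-trihydroxyphenyl and 3,4-dihydroxyphenyl stand clearly apart. The wider steps, a 28-fold lower number from compound 2 to compound 4 (1.45 log units; beyond the scatter) and a 16-fold lower number from compound 1 to compound 4 (1.21 log units; beyond the scatter), show how far this position can move the number, and compound 4 has the lowest of the four.

From the compounds shown here alone, whether a 2,4-dihydroxyphenyl ring, or an amine or a carboxylic acid in place of a hydroxyl group, would keep this drop remains open. The compounds shown also give no measured reason for the drop.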